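A few compounds are considered here, and "the series" means these few. Any claim that something is new, unique, unknown or untested is made for them only; others in the source may bear on it.

Compounds measured so far:
compound 1 `O=S(=O)(c1ccc(Cl)cc1)N1CC(c2nc(-c3cccc(Cl)c3)no2)C1` — 170 nM
compound 2 `CC1CCC(C(=O)N2CC(c3nc(-c4cccc(Cl)c4)no3)C2)CC1` — > 10000 nM
compound 3 `O=C(C1CCC(C(F)(F)F)CC1)N1CC(c2nc(-c3cccc(Cl)c3)no2)C1` — > 10000 nM

Compound 1 is measured in an assay on HEK293 cells for negative allosteric modulation of metabotropic glutamate receptor 5 (Homo sapiens), read by FLIPR (a lower number here means a stronger inhibitor, a higher number a weaker inhibitor), and gives 170 nM. Compound 2 gives only the limit > 10000 nM in this assay; no number is known for it. Compound 3 likewise sits at a limit, > 10000 nM. The step that the two limits leave unreadable from compound 2 to compound 3 is therefore unreadable because both values sit at the limit of > 10000 nM in this assay, at which 2 of the 3 values shown sit. Compound 2 thus stands at the reporting boundary of this assay, whereas compound 1 gives a number within the measured range.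

Compound 4 `O=C(C1CCC1)N1CC(c2nc(-c3cccc(Cl)c3)no2)C1` differs from compound 2 by cyclobutyl in place of 4-methylcyclohexyl on a carbonyl carbon. For the measured compounds named here, no measured step covers a change of this kind on the carbonyl carbon; the only step on that part of the molecule, a step that the two limits leave unreadable from compound 2 to compound 3, is unreadable. Going by the values given here, both carbonyl-bearing compounds measured so far sit at the limit, so the expectation for compound 4 is that it also stays at or near the limit, with the step of a number no higher from compound 2 to compound 4 (the limit leaves the size open) expected to be small or not visible. Compound 4 is therefore estimated at 10000 nM, with a range of 2500 nM to 30000 nM, and this assay is expected most likely to report only a limit once more.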

Compound 4, half-maximal inhibitory concentration: 1500 nM
Compound 4: middle estimate off by 6.7-fold (0.82 log units), on the high side, outside the stated range (below it).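

In this assay, cyclobutyl in place of 4-methylcyclohexyl on the carbonyl carbon gives an at least 6.6-fold lower number from compound 2 to compound 4 (0.82 log units; beyond the scatter), so this position can carry a carbonyl-linked group and still return a number rather than a limit. Both groups are carbon-only rings with no hydrogen-bond donors or acceptors, so the change in this pair lies in the ring and its substituent, not in any added heteroatom. The earlier step from compound 2 to compound 3 cannot be read, and the true size of the new step also stays open, because compound 2 sits at a limit rather than a number: the limit of > 10000 nM in this assay, at which 2 of the 4 values shown sit.

A single pair cannot separate ring size from the removal of the methyl, and a cyclopentyl, an unsubstituted cyclohexyl or a cyclopropyl on the same carbonyl carbon would be needed to tell these apart. Also open, on these data alone, is how this position responds to a group that brings in heteroatoms, such as a carboxylic acid or an amine on the cyclobutyl ring.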